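A few compounds are considered here, and "the series" means these few. Any claim that something is new, unique, unknown or untested is made for them only; others in the source may bear on it.

Values so far in a functional assay on HUVEC cells (Homo sapiens), read by scintillation counting and thymidine incorporation, with a stated time of 24 h (a higher number here means a weaker inhibitor, a lower number a stronger inhibitor), for three compounds

compound 1 `CCC(C)n1ncn(-c2ccc(N3CCN(c4ccc(OC[C@@H]5CO[C@@](CN6CCN(C)CC6)(c6ccc(Cl)cc6Cl)O5)cc4)CC3)cc2)c1=O` gives 396 nM
compound 2 `CCC(C)n1ncn(-c2ccc(N3CCN(c4ccc(OC[C@@H]5CO[C@@](Cn6cnc(C)c6)(c6ccc(Cl)cc6Cl)O5)cc4)CC3)cc2)c1=O` gives 102 nM
compound 3 `CCC(C)n1ncn(-c2ccc(N3CCN(c4ccc(OC[C@@H]5CO[C@@](Cn6cccn6)(c6ccc(Cl)cc6Cl)O5)cc4)CC3)cc2)c1=O` gives 307 nM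

Compound 3 cannot be told apart from compound 1, since the step between them is a 1.3-fold lower number from compound 1 to compound 3 (0.11 log units; within the scatter) on this measure. Compound 2 is the strongest inhibitor of the set, and the step to its neighbour is a 3.0-fold higher number from compound 2 to compound 3 (0.48 log units; beyond the scatter) in the other direction.

Compound 4 `CCC(C)n1ncn(-c2ccc(N3CCN(c4ccc(OC[C@@H]5CO[C@@](Cn6nnnc6-c6ccccc6)(c6ccc(Cl)cc6Cl)O5)cc4)CC3)cc2)c1=O` has not been measured yet. It keeps the shared core and carries 5-phenyl-1H-tetrazol-1-yl in place of 1H-pyrazol-1-yl on a saturated chain carbon bound to a saturated ring carbon, a change counted as 5-phenyl-1H-tetrazol-1-yl in place of 1H-pyrazol-1-yl on a saturated chain carbon bound to a saturated ring carbon in full.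

Within the data shown here, all the measured steps concern this same place. Those two steps and a 3.9-fold lower number from compound 1 to compound 2 (0.59 log units; beyond the scatter) as the third show that swaps here have so far been modest or lost in the scatter. Among the measured compounds shown here, none of the measured compounds carries a phenyl group at this place, so the data offer no firm direction for the new group. In this assay no step beyond the scatter is therefore expected. The estimated step is a 1.1-fold lower number from compound 3 to compound 4 (0.04 log units; within the scatter) and no more than that. For compound 4 the estimated value is 280 nM with an expected range from 90 nM to 850 nM in this measurement.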

Compound 4, half-maximal inhibitory concentration: 119 nM
Beside the measured number, compound 4's estimate is 2.4-fold (0.37 log units) above it; measured number inside the range.
By their numbers in this assay, from the lowest: compounds 2 and 4 (each within the scatter of the next); then compounds 3 and 1 (each within the scatter of the next).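

In this assay, this place takes a much bigger group without any loss: 5-phenyl-1H-tetrazol-1-yl has 11 heavy atoms where 1H-pyrazol-1-yl has 5, yet the number falls (a 2.6-fold lower number from compound 3 to compound 4 (0.41 log units; beyond the scatter)). The new group also stands clear of 4-methylpiperazin-1-yl (a 3.3-fold lower number from compound 1 to compound 4 (0.52 log units; beyond the scatter)) but cannot be told apart from 4-methyl-1H-imidazol-1-yl (a 1.2-fold higher number from compound 2 to compound 4 (0.07 log units; within the scatter)), so two quite different groups now share the low end of the set, while 1H-pyrazol-1-yl, also an aromatic ring, stays at the high end with 4-methylpiperazin-1-yl. Nothing measured here explains why this swap gives a lower number.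

The compounds shown include neither a tetrazol-1-yl group without its phenyl ring nor a pyrazol-1-yl group carrying a phenyl ring, so the part each ring plays in this step remains open. Also open, going by these compounds, is whether a chlorophenyl ring on the tetrazole, or an open-chain amine such as dimethylamino at this place, would keep the number as low.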